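The source may report more compounds than this note shows. Statements on the series, on what has been measured and on what is new or still open speak of the compounds shown alone.

Measured so far in an ADME assay on MDCK cells (Canis lupus familiaris) for cytotoxicity, read by MTT assay, with a stated time of 48 h; on this read-out lower numbers stand for higher toxicity in this test and higher numbers for lower toxicity in this test:

- compound 1 `COc1ccc(OC)c([C@H]2CC(C)(O)[C@@H]3CC[C@@H](C)C[C@H]3O2)c1`: 512000 nM
- compound 2 `COc1ccc([C@H]2CC(C)(O)[C@@H]3CC[C@@H](C)C[C@H]3O2)cc1OC`: a limit of the assay, > 937000 nM
- compound 3 `COc1cc(OC)c([C@H]2CC(C)(O)[C@@H]3CC[C@@H](C)C[C@H]3O2)cc1OC`: a limit of the assay, > 857000 nM

Compound 3 stands at the upper edge of what this assay reports, (the limit of > 857000 nM in this assay, at which 1 of the 3 values shown sits). Compound 2 likewise sits at a limit, (the limit of > 937000 nM in this assay, at which 1 of the 3 values shown sits), so only compound 1 carries a read number. The step from compound 1 to compound 3 is an at least 1.6-fold higher number from compound 1 to compound 3 (0.22 log units; that floor lies within the scatter), a methoxy in place of hydrogen on an aromatic carbon. The step from compound 2 to compound 3 is a step that the two limits leave unreadable from compound 2 to compound 3, the same kind of change; with both ends at limits it tells nothing about size. Across all three compounds the series thus shows low toxicity in this assay and no step that can be read as beyond the scatter.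

Compound 4 `COc1cc(OC)c([C@H]2CC(C)(F)[C@@H]3CC[C@@H](C)C[C@H]3O2)cc1OC` differs from compound 3 by fluoro in place of hydroxy on a saturated ring carbon. Among the measured compounds shown here, none of the measured steps touches this saturated ring position; both concern aromatic methoxy groups. There is therefore no measured basis to expect a step beyond the scatter in this assay, and compound 4 is expected near the limit where compound 3 sits. The estimate for compound 4 is 750000 nM, within 250000 nM to 1000000 nM, which as a step means an expected at least 1.1-fold lower number from compound 3 to compound 4 (0.05 log units; that floor lies within the scatter).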

Compound 4, half-maximal cytotoxic concentration: 78000 nM
Compound 4: the middle estimate sits 9.6-fold (0.98 log units) above what was measured; the whole stated range lies above it.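

In this assay, among the compounds shown here, the saturated ring carbon that bears the hydroxy is the first place where a single change gives a step that can be read, as the earlier aromatic methoxy steps showed nothing beyond the scatter. Fluoro in place of hydroxy at this carbon gives an at least 10-fold lower number from compound 3 to compound 4 (1.04 log units; beyond the scatter), which on this read-out means higher toxicity in this test and shows that this change is not neutral on the shared core. The value of compound 3 is a limit of the assay, so the size of this step is a floor and not a full measure: the limit of > 857000 nM in this assay, at which 1 of the 4 values shown sits.

On these data alone, one exchange cannot separate the loss of the hydroxy from the arrival of the fluoro, so it remains open which of the two carries the step, and a methoxy or an amine at the same carbon would be needed to tell them apart. As far as these compounds go, it also remains open whether the same exchange gives a step of this size with the aromatic methoxy patterns of compound 1 and compound 2.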